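The compounds below may be only part of what the source reports. "The series", "measured", "known", "first", "only" and "open" are said of these compounds alone.

In a functional assay on NB-4 cells (Homo sapiens) for antiproliferative activity, read by MTT assay, with a stated time of 48 h (a higher number here means a weaker inhibitor, a lower number a stronger inhibitor), three compounds built on the same core have been measured. Compound 1 `CC(C)[C@H](NC(=O)c1ccc(C(=O)Nc2ccc3c(c2)C(C)(C)CCC3(C)C)cc1)C(=O)OCc1c(-c2ccccc2)no[n+]1[O-]` gives 4390 nM. Compound 2 `CC(C)C[C@H](NC(=O)c1ccc(C(=O)Nc2ccc3c(c2)C(C)(C)CCC3(C)C)cc1)C(=O)OCc1c(-c2ccccc2)no[n+]1[O-]` gives 970 nM. Compound 3 `CC1(C)CCC(C)(C)c2cc(NC(=O)c3ccc(C(=O)OCCCCCCOC(=O)c4ccc(OCc5c(-c6ccccc6)no[n+]5[O-])cc4)cc3)ccc21` reaches only a limit of the assay, > 1000000 nM, and no number is known for it.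

Among the two numbers shown, compound 2 stands lowest, with compound 1 as its nearest neighbour, the gap being a 4.5-fold lower number from compound 1 to compound 2 (0.66 log units; beyond the scatter). That step is the only measured one, and it moves the number by a modest amount in the direction of a stronger inhibitor when the chain grows by one carbon.

Compound 4 `C[C@H](NC(=O)c1ccc(C(=O)Nc2ccc3c(c2)C(C)(C)CCC3(C)C)cc1)C(=O)OCc1c(-c2ccccc2)no[n+]1[O-]` has not yet been measured in this assay. It differs from compound 2 by hydrogen in place of isopropyl on a saturated chain carbon, two bonds along the chain from an amide-type nitrogen and a carbonyl carbon. This change runs against the measured step: where compound 1 to compound 2 added a carbon, compound 2 to compound 4 removes the whole branch. A step of modest size toward a higher number is therefore expected, estimated as a 3.1-fold higher number from compound 2 to compound 4 (0.49 log units; beyond the scatter). Compound 4 is expected to give about 3000 nM, within a range from 700 nM to 12000 nM.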

Compound 4, half-maximal inhibitory concentration: 5100 nM
For compound 4 the middle estimate is 1.7-fold (0.23 log units) below the measured one; measured number inside the range.
By their numbers in this assay, from the lowest: compound 2; then compounds 1 and 4 (each within the scatter of the next). At a limit, above all of these: compound 3.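

In this assay, removing the branch shows that the isobutyl group on this saturated chain carbon, bound to an amide-type nitrogen and a carbonyl carbon, can be traded for methyl only at a cost: a 5.3-fold higher number from compound 2 to compound 4 (0.72 log units; beyond the scatter). The methyl and isopropyl groups, by contrast, cannot be told apart, with a 1.2-fold higher number from compound 1 to compound 4 (0.07 log units; within the scatter), so among the three compounds the number does not follow chain size step by step, and only compound 2 stands apart. Nothing available here bears on why isobutyl stands apart from the two smaller groups.

The compounds shown leave open whether a longer chain or a benzyl group on this carbon would extend the gain seen with isobutyl or lose it. They also leave open how an amine or a carboxylic acid at the end of such a chain would read.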